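The source may report more compounds than this note shows. Statements on the series, on what has been measured and on what is new or still open speak of the compounds shown alone.

In a functional assay on RKO cells (Homo sapiens) for cytotoxicity, read by resazurin assay, with a stated time of 72 h (a higher number here means a weaker inhibitor, a lower number a stronger inhibitor), three compounds have been read so far. Going by the values given here, compound 1 (`Cc1nc2ccccc2n1-c1csc(Nc2cccc(Br)c2)n1`) gives 85000 nM, the only true number among them. Compound 2 (`Cc1nccn1-c1csc(Nc2cccc(Br)c2)n1`) reads > 100000 nM, which is a limit of the assay. Compound 3 (`Brc1ccc(Nc2nc(-n3cnc4ccccc43)cs2)cc1`) reads > 100000 nM, which is likewise a limit and not a number. The set is therefore dominated by the limit of > 100000 nM in this assay, at which 2 of the 3 values shown sit, and compound 3 stands among that pair.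

Compound 4 (`c1ccc(Nc2nc(-n3cnc4ccccc43)cs2)cc1`) has not yet been measured. It carries hydrogen in place of bromo on an aromatic carbon, para to a large group, so that 4-bromophenyl becomes phenyl: hydrogen in place of bromo on an aromatic carbon. Among the compounds with values here, no measured pair isolates this change. Within the data shown here, compound 1, at 85000 nM, is the only member to give a number, so no step beyond the scatter is expected in this assay, in either direction. The expected step, a number no higher from compound 3 to compound 4 (the limit leaves the size open), is only an estimate set against a limit. For compound 4 the estimated value is 100000 nM, with an expected range of 40000 nM to 150000 nM.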

Compound 4, half-maximal inhibitory concentration: > 100000 nM
Compound 4: no number, only a limit (the forecaster's own chance of this, stated with the estimate: 65%); the middle value lies on the limit itself.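

No step can be read from compound 3 to compound 4 in this assay, because both values are limits and not numbers: the limit of > 100000 nM in this assay, at which 3 of the 4 values shown sit. The compounds shown leave open what hydrogen in place of bromo on an aromatic carbon does to the read-out.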